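The compounds below may be only part of what the source reports. "The series", "measured", "known", "first", "only" and "open" are said of these compounds alone.

Among the compounds with values here, compound 1, `O=S(=O)(NCCCCCCNCc1ccc(Br)cc1)c1cc(Cl)cc(Cl)c1`, is the weakest grower-inhibitor among the three compounds measured so far in a functional assay on MIA PaCa-2 cells (Homo sapiens) for inhibition, read by MTT assay, with a stated time of 72 h (a lower number here means a stronger inhibitor of growth, a higher number a weaker inhibitor of growth), where compound 1 gives 12000 nM. Compound 3, `O=S(=O)(NCCCNCc1ccccc1)c1cc(C(F)(F)F)cc(C(F)(F)F)c1`, gives 11000 nM in this assay, a value within the usual scatter of that of compound 1. Compound 2, `CCCCc1ccc(S(=O)(=O)NCCCCCCNCc2ccc(Br)cc2)cc1`, gives a lower number, 5700 nM, in this assay. Compound 4, `O=[N+]([O-])c1ccccc1S(=O)(=O)NCCCCCCNCc1ccc(Br)cc1`, has not yet been measured; it differs from compound 1 in one place: 2-nitrophenyl in place of 3,5-dichlorophenyl on a sulfonyl sulfur. Within the data shown here, no pair of measured compounds shows what such a swap does, so the expected step from compound 1 to compound 4 is a 1.2-fold higher number from compound 1 to compound 4 (0.07 log units; within the scatter), a step not expected to reach beyond the scatter in either direction. For compound 4 the expected value in this assay is therefore 14000 nM, with a range from 5000 nM to 40000 nM.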

Compound 4, concentration for 50% growth inhibition: 11700 nM
Beside the measured number, compound 4's estimate is 1.2-fold (0.08 log units) above it; measured number inside the range.
By their numbers in this assay, from the lowest: compounds 2, 3, 4 and 1 (each within the scatter of the next, the first and the last beyond it).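

In this assay the swap of 3,5-dichlorophenyl for 2-nitrophenyl on a sulfonyl sulfur gives a 1.0-fold lower number from compound 1 to compound 4 (0.01 log units; within the scatter) and so leaves the two compounds indistinguishable. This place therefore accepts two differently substituted aromatic rings, one with no hydrogen-bond acceptors and one with two, without a step beyond the scatter. No measurement available here explains why the two compounds read alike. Still open, as far as these compounds go, is whether the same holds for a group of another kind on that sulfur, such as a plain methyl group or an aminophenyl ring.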